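Swapping the heteroaryl on the thioether of compound 2

The source may hold more compounds than are shown below. What is called first, only, known or untested is meant among the compounds shown, and "the series" means these compounds.

Measured compounds:
compound 1 `Cn1c(-c2ccc(NC(=O)CSc3nc4cc(Cl)ccc4o3)cc2)nc(-c2ccccc2)c1-c1ccccc1` gives 21.7 ug/mL
compound 2 `Cc1nnc(SCC(=O)Nc2ccc(-c3nc(-c4ccccc4)c(-c4ccccc4)n3C)cc2)s1` gives 3.2 ug/mL

Both numbers come from a functional assay on MCF7 cells (Homo sapiens) for cytotoxicity, read by MTT assay, with a stated time of 24 h; a higher number here means a weaker inhibitor, a lower number a stronger inhibitor. Compound 2 has the lowest number of the two; its nearest neighbour is compound 1, and the step of a 6.8-fold lower number from compound 1 to compound 2 (0.83 log units; beyond the scatter) lies beyond the scatter.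

Compound 3 `Cn1c(-c2ccc(NC(=O)CSC3=NCCS3)cc2)nc(-c2ccccc2)c1-c1ccccc1` is unmeasured. It differs from compound 2 in one place: a group of 5 heavy atoms (3 carbon, 1 nitrogen, 1 sulfur; one five-membered non-aromatic ring with 2 hetero atoms) in place of a group of 6 heavy atoms (3 carbon, 2 nitrogen, 1 sulfur; one five-membered aromatic ring with 3 hetero atoms), on a sulfur. Going by the values given here, the only measured step at this position is the one from compound 1 to compound 2, where a smaller aromatic ring replaced a larger one and the number fell. The present change keeps the ring small but removes its aromatic character and one acceptor, so the earlier step gives only loose guidance.

For compound 3 in this assay the expected step is a 1.9-fold higher number from compound 2 to compound 3 (0.27 log units; within the scatter), most likely within the scatter or a modest rise. The estimate for compound 3 is 6 ug/mL, in the range 2 ug/mL to 20 ug/mL.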

Compound 3, half-maximal inhibitory concentration: 26.7 ug/mL
Compound 3: the middle estimate sits 4.5-fold (0.65 log units) below what was measured; the whole stated range lies below it.
By their numbers in this assay, from the lowest: compound 2; then compounds 1 and 3 (each within the scatter of the next).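

In this assay, a small ring on the sulfur is not enough to keep the low number of the 5-methyl-1,3,4-thiadiazol-2-yl: the non-aromatic five-membered ring gives a clear rise (an 8.3-fold higher number from compound 2 to compound 3 (0.92 log units; beyond the scatter)). This ring and the much larger 5-chloro-1,3-benzoxazol-2-yl cannot be told apart (a 1.2-fold higher number from compound 1 to compound 3 (0.09 log units; within the scatter)), so ring size alone does not order these three compounds, and only the thiadiazole stands out among them. Nothing on hand explains why this group differs from the other two.

From the compounds shown here alone, it remains open whether the aromatic ring or its methyl matters more, as the thiadiazole appears here only with that methyl. Going by these compounds, how the same ring would read with an amine or an ethyl group in place of the methyl also remains unknown.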